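A few compounds are considered here, and "the series" means these few. Any claim that something is new, unique, unknown or untested is made for them only; others in the source may bear on it.

The measured compounds are:

compound 1, `CC/N=C(\S)NCCCCCn1nc(-c2ccccc2)ccc1=O`, 66.4%
compound 2, `CC/N=C(/NC#N)NCCCCn1nc(-c2ccccc2)ccc1=O`, 58.8%
compound 3, `C=CCNC(=S)NCCCCn1nc(-c2ccccc2)ccc1=O`, 27.1%

All three numbers come from a functional assay on the whole organism with Rattus norvegicus as the target, at a dose of 100 mg/kg; a higher number here means more inhibition at the dose given (going by the name of the read-out), a lower number less inhibition. Compound 3 stands lowest of the three; its nearest neighbour is compound 2, at a number 31.7 percentage points lower from compound 2 to compound 3 (beyond the scatter), and its furthest neighbour is compound 1, at a number 39.3 percentage points lower from compound 1 to compound 3 (beyond the scatter), both beyond the scatter.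

Compound 4, `C/N=C(/NC#N)N(C)CCCCn1nc(-c2ccccc2)ccc1=O`, is not yet measured. It differs from compound 3 in one place: a group of 8 heavy atoms (4 carbon, 4 nitrogen; no ring) in place of a group of 7 heavy atoms (4 carbon, 2 nitrogen, 1 sulfur; no ring), on a saturated chain carbon, four bonds along the chain from an aromatic nitrogen.

Within the data shown here, two measured steps bear on this. The step of a number 7.6 percentage points lower from compound 1 to compound 2 (within the scatter) shows that exchanging the sulfur-bearing group for the nitrogen-rich group of the same kind cost little. The step of a number 31.7 percentage points lower from compound 2 to compound 3 (beyond the scatter) shows that the reverse sort of exchange, together with a change of the alkyl substituent, went with a large loss. Reading the change from compound 3 to compound 4 as broadly the reverse of that second step, a clear rise in this assay is expected, though compound 4 carries smaller alkyl groups than either compound 1 or compound 2, so the rise is estimated to fall short of the full span.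

For compound 4 the expected value is 50%, within 25% to 75%, an estimated step of a number 22.9 percentage points higher from compound 3 to compound 4 (beyond the scatter).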

Compound 4, a percentage reported as inhibition, in the whole organism at one dose (the size of the read-out at that dose, not a potency): 27%
Beside the measured number, compound 4's estimate is 23 percentage points above it, and the stated range covers the measured number.
By their numbers in this assay, from the lowest: compounds 4 and 3 (each within the scatter of the next); then compounds 2 and 1 (each within the scatter of the next).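

In this assay, the group of 8 heavy atoms (4 carbon, 4 nitrogen) in place of the sulfur-bearing group of 7 heavy atoms gives a number 0.1 percentage points lower from compound 3 to compound 4 (within the scatter), so at this place the all-nitrogen group does not by itself bring a high number. Compound 2 carries a group with the same atom count, yet the record shows a number 31.8 percentage points lower from compound 2 to compound 4 (beyond the scatter), and the sulfur-bearing compound 1 likewise stands apart with a number 39.4 percentage points lower from compound 1 to compound 4 (beyond the scatter), so the arrangement of the group matters here and not merely its atoms. No measurement shown here explains these differences.

The compounds shown leave open which feature of the group in compound 4 accounts for its gap from compound 2. They also leave open how a urea or a propyl group would read at this place.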